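This account rests on a few compounds, and the source may have more. Where it says the series, first, only, none or still open, it means among the compounds named here.

Measured so far:
Compound 1 `COc1ccc(S(=O)(=O)N(CC(N)=O)c2ccc(N(CC(N)=O)S(=O)(=O)c3ccc([S+]([O-])CCN=C=S)cc3)c3ccccc23)cc1` in an ADME assay on cells (Peritoneal macrophage, Mus musculus) for cytotoxicity, read by CCK-8 assay, with a stated time of 24 h (on this read-out higher numbers stand for lower toxicity in this test and lower numbers for higher toxicity in this test), gives > 10000 nM, which is a limit of the assay and not a number.
Compound 2 `COc1ccc(S(=O)(=O)N(CC(N)=O)c2ccc(N(CC(N)=O)S(=O)(=O)c3ccc([S+]([O-])CCOCCN=C=S)cc3)c3ccccc23)cc1` in this assay gives > 10000 nM, again a limit.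
Compound 3 `COc1ccc(S(=O)(=O)N(CC(N)=O)c2ccc(N(CC(N)=O)S(=O)(=O)c3ccc(S(=O)(=O)CCOCCN=C=S)cc3)c3ccccc23)cc1` in this assay gives > 10000 nM, again a limit.

Among the compounds with values here, every reading so far sits at the limit of > 10000 nM in this assay, at which 3 of the 3 values shown sit. The change a group of 6 heavy atoms (3 carbon, 1 nitrogen, 1 oxygen, 1 sulfur; no ring) in place of a group of 3 heavy atoms (1 carbon, 1 nitrogen, 1 sulfur; no ring), on a saturated chain carbon, two bonds along the chain from a sulfur therefore produced a step that the two limits leave unreadable from compound 1 to compound 2. The cores of compound 1 and compound 3 differ by a group of 11 heavy atoms (5 carbon, 1 nitrogen, 3 oxygen, 2 sulfur; no ring) in place of a group of 7 heavy atoms (3 carbon, 1 nitrogen, 1 oxygen, 2 sulfur; no ring), on an aromatic carbon, and this change produced a step that the two limits leave unreadable from compound 1 to compound 3. Likewise there is a step that the two limits leave unreadable from compound 2 to compound 3. No ordering among the three measured compounds can be read from these values.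

Compound 4 `COc1ccc(S(=O)(=O)N(CC(N)=O)c2ccc(N(CC(N)=O)S(=O)(=O)c3ccc(S(=O)(=O)CCOCCOCCN=C=S)cc3)c3ccccc23)cc1` is not yet measured in this assay. It differs from compound 3 by a group of 6 heavy atoms (3 carbon, 1 nitrogen, 1 oxygen, 1 sulfur; no ring) in place of a group of 3 heavy atoms (1 carbon, 1 nitrogen, 1 sulfur; no ring), on a saturated chain carbon, two bonds along the chain from an oxygen on a saturated carbon. Within the data shown here, this is the same kind of change as the one from compound 1 to compound 2, but not the same: in the earlier case the place was on a saturated chain carbon, two bonds along the chain from a sulfur, whereas here it is on a saturated chain carbon, two bonds along the chain from an oxygen on a saturated carbon.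

In this assay the step from compound 3 to compound 4 is expected to be a step that the limit leaves unreadable from compound 3 to compound 4, which rests on compound 1 and compound 2 both sitting at the limit of > 10000 nM in this assay, at which 3 of the 3 values shown sit, across the earlier change. Compound 4 is accordingly expected to give 20000 nM, with a range from 10000 nM to 60000 nM, and most likely only a limit will be reported.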

Compound 4, half-maximal cytotoxic concentration: > 10000 nM
Compound 4 was reported as a limit; the forecaster's own chance of this, stated with the estimate: 85%; the middle value lies beyond the limit too.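

In this assay compound 4 gives > 10000 nM, which is a limit of the assay and not a number. No step from compound 3 to compound 4 can be read, as both sit at the same limit: the limit of > 10000 nM in this assay, at which 4 of the 4 values shown sit.

The compounds shown leave open at what concentration compound 1, compound 2, compound 3 and compound 4 would become cytotoxic, and whether they differ from one another in this assay.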